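The compounds below may be only part of what the source reports. "The series", "measured", "known", "first", "only" and "open" are said of these compounds alone.

Measured in a functional assay on B16 cells (Mus musculus) for cytotoxicity, read by CCK-8 assay, with a stated time of 24 h; a lower number here means a stronger inhibitor, a higher number a weaker inhibitor:
Compound 1 `COc1ccc(-c2nc(N)c(Oc3ccccc3OC)c(Cl)n2)cc1`: 47800 nM
Compound 2 `COc1ccccc1Oc1c(N)nc(-c2ccccc2)nc1OCCO`: 31100 nM
Compound 3 `COc1ccccc1Oc1c(N)nc(-c2cccc(C)c2)nc1OCCO`: 70900 nM

Compound 3 lies within the scatter of compound 1 and stands clear of one neighbour only: the data show a 2.3-fold higher number from compound 2 to compound 3 (0.36 log units; beyond the scatter), a modest step, for methyl in place of hydrogen on an aromatic carbon. Compound 4 `COc1ccc(-c2nc(N)c(Oc3ccccc3OC)c(OCCO)n2)cc1` has 4-methoxyphenyl in place of 3-methylphenyl on an aromatic carbon. For the measured compounds named here, no measured step covers this exchange directly. The nearest guide is compound 1 at 47800 nM, which also carries 4-methoxyphenyl but differs elsewhere. A small move toward a lower number is therefore expected, probably within the scatter. The expected change is a 1.6-fold lower number from compound 3 to compound 4 (0.20 log units; within the scatter). For compound 4 the estimated value is 45000 nM, with an expected range from 20000 nM to 100000 nM.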

Compound 4, half-maximal inhibitory concentration: 18100 nM
Beside the measured number, compound 4's estimate is 2.5-fold (0.40 log units) above it, and the stated range ends above it.
By their numbers in this assay, from the lowest: compounds 4, 2, 1 and 3 (each within the scatter of the next, the first and the last beyond it).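

On the aromatic carbon between two ring nitrogen atoms, 4-methoxyphenyl in place of 3-methylphenyl gives a 3.9-fold lower number from compound 3 to compound 4 (0.59 log units; beyond the scatter), so a substituent on this phenyl need not raise the number as the methyl did. Methoxy in place of hydrogen gives a 1.7-fold lower number from compound 2 to compound 4 (0.24 log units; within the scatter), leaving compound 4 and compound 2 not clearly apart. A second place also matters, since 2-hydroxyethoxy in place of chloro gives a 2.6-fold lower number from compound 1 to compound 4 (0.42 log units; beyond the scatter). Nothing at hand explains these steps. Still open, on these data alone, is how 3-methoxyphenyl or 4-methylphenyl would read here, and how an amine or a longer chain would compare with 2-hydroxyethoxy.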